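Compound 3 to compound 4: chloro to methoxycarbonyl

The source may hold more compounds than are shown below. What is called first, only, known or untested is meant among the compounds shown, and "the series" means these compounds.

Values in an ADME assay on S9 fraction from liver (Rattus norvegicus) for metabolic stability, read by LC-MS, using NADPH, with a stated time of 30 min; a lower number here means that less of the compound is left, a higher number that more of the compound is left:
- compound 1 `CC(Oc1ccc(Oc2ccc(F)cc2)cc1)C(=O)Cn1nnc(-c2ccc(Cl)cc2)n1`: < 5%, a limit of the assay
- compound 2 `CC(Oc1ccc(Oc2ccc(Cl)cc2)cc1)C(=O)Cn1nnc(-c2ccc(Cl)cc2)n1`: < 5%, a limit of the assay
- compound 3 `CC(Oc1ccc(-c2ccccc2)cc1)C(=O)Cn1nnc(-c2ccc(Cl)cc2)n1`: 18%

Going by the values given here, compound 3 is the only compound here with a readable number. Compound 1 and compound 2 stand at the limit of < 5% in this assay, at which 2 of the 3 values shown sit. Compound 4 `COC(=O)c1ccc(-c2nnn(CC(=O)C(C)Oc3ccc(-c4ccccc4)cc3)n2)cc1` carries methoxycarbonyl in place of chloro on an aromatic carbon, para to a large group: methoxycarbonyl in place of chloro on an aromatic carbon. The measured steps are a step that the two limits leave unreadable from compound 1 to compound 2, a number at least 13 percentage points higher from compound 1 to compound 3 (beyond the scatter) and a number at least 13 percentage points higher from compound 2 to compound 3 (beyond the scatter). All three changed a different place in the molecule, so none of them measures this swap. With only compound 3 at 18% to start from, no step beyond the scatter is expected, and the expected step is a number 8 percentage points lower from compound 3 to compound 4 (within the scatter). Compound 4 is estimated at 10%, with an expected range of 3% to 25%.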

Compound 4, percent of the compound remaining: 21%
Compound 4: middle estimate off by 11 percentage points, on the low side; the range from low to high includes it.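

Going by these compounds alone, compound 3 and compound 4 give the first reading at this position, as the earlier steps all changed a different place in the molecule. In this assay the swap of chloro for methoxycarbonyl, on an aromatic carbon para to a large group, gives a number 3 percentage points higher from compound 3 to compound 4 (within the scatter) and so leaves the read-out level despite the larger group entering. No measurement at hand gives a cause for this result.

From the compounds shown here alone, a carboxylic acid, an amine or a longer chain on this aromatic carbon remains open. So does whether the swap reads the same with a 4-chlorophenoxy group in place of the phenyl.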